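The source may report more compounds than this note shows. Statements on the series, on what has been measured and on what is new or still open speak of the compounds shown alone.

Compound 1 `Cc1nc(C)c(-c2nn(-c3ccc(F)cc3)cc2/C=C/C(=O)c2cc(Cl)ccc2O)s1`, compound 2 `Cc1nc(C)c(-c2nn(-c3ccc(F)cc3)cc2/C=C/C(=O)c2c(O)cc(C)c(Cl)c2C)s1`, compound 3 `Cc1nc(C)c(-c2nn(-c3ccc(F)cc3)cc2C2CC(c3cc(Cl)ccc3O)=NN2)s1`.

In an ADME assay on HeLa cells (Homo sapiens) for inhibition, read by MTT assay (on this read-out lower numbers stand for stronger inhibition of growth and higher numbers for weaker inhibition of growth), compound 1 reaches only the limit, > 250 ug/mL. Compound 2 gives 59.3 ug/mL in this assay. Compound 3 also stops at the limit, > 250 ug/mL, so where it stands is a limit and not a number. Two of the three values sit at that limit (the limit of > 250 ug/mL in this assay, at which 2 of the 3 values shown sit). Compound 4 `Cc1nc(C)c(-c2nn(-c3ccc(F)cc3)cc2C2CC(c3c(O)cc(C)c(Cl)c3C)=NN2)s1` differs from compound 3 by 3-chloro-6-hydroxy-2,4-dimethylphenyl in place of 5-chloro-2-hydroxyphenyl on a carbon with a double bond to nitrogen. Within the data shown here, the one measured step carrying the same change of aryl group, an at least 4.2-fold lower number from compound 1 to compound 2 (0.62 log units; beyond the scatter), moved from a limit to a number; a step of similar direction is therefore expected here, an at least 2.7-fold lower number from compound 3 to compound 4 (0.44 log units; beyond the scatter), its size uncertain since the start is a limit. Compound 4 is estimated at 90 ug/mL, within 30 ug/mL to 300 ug/mL.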

Compound 4, concentration for 50% growth inhibition: 25.2 ug/mL
For compound 4 the middle estimate is 3.6-fold (0.55 log units) above the measured one; measured number outside the range, below it.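

In this assay, 3-chloro-6-hydroxy-2,4-dimethylphenyl in place of 5-chloro-2-hydroxyphenyl gives an at least 9.9-fold lower number from compound 3 to compound 4 (0.99 log units; beyond the scatter), so the direction seen on a carbonyl carbon also holds on a carbon with a double bond to nitrogen of a five-membered non-aromatic ring. Both matched pairs now agree, and none goes against them. Each step size remains a lower bound, and the two sizes cannot be compared: the limit of > 250 ug/mL in this assay, at which 2 of the 4 values shown sit.

Open, as far as these compounds go, is whether the methyl groups or the changed chlorine placement carry the step. Also open, from the compounds shown here alone, is whether a methoxy or an amine in place of the hydroxy would keep it.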